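Two Limits and a New Amide Side Chain

The source may report more compounds than this note shows. Statements on the series, on what has been measured and on what is new or still open speak of the compounds shown alone.

Compound 2 `Nc1ccc2c(c1)S(=O)(=O)C=C(c1c(O)c3cc(F)ccc3n(Cc3ccc(F)cc3)c1=O)N2` was examined in an ADME assay on 2209-23 cells (Homo sapiens) for cytotoxicity, read by WST assay; a lower number here means that less compound is tolerated, a higher number that more compound is tolerated. In this assay compound 2 gives > 50000 nM, which is a limit of the assay and not a number. Its only close relative, compound 1 `O=c1c(C2=CS(=O)(=O)c3cc(F)ccc3N2)c(O)c2cc(F)ccc2n1Cc1ccc(F)cc1`, carries a fluoro group where compound 2 carries an amino group. In this assay compound 1 gives > 50000 nM, again a limit. Between them the step is a step that the two limits leave unreadable from compound 1 to compound 2. Both values sit at the limit of > 50000 nM in this assay, at which 2 of the 2 values shown sit, so no size of any step can be read from this pair. Compound 3 `CNC(=O)COc1ccc2c(c1)S(=O)(=O)C=C(c1c(O)c3cc(F)ccc3n(Cc3ccc(F)cc3)c1=O)N2` is not yet measured. The change is (methylcarbamoyl)methoxy in place of amino on an aromatic carbon. Among the measured compounds shown here, the one measured step bears on it only in that it also exchanged a group on an aromatic carbon of the shared core, and it left no readable size. No step beyond the scatter is expected in this assay. The estimate for compound 3 is 50000 nM, with a range from 25000 nM to 100000 nM, and most likely the assay will again report only a limit. The step this estimate implies is a number no higher from compound 2 to compound 3 (the limit leaves the size open), an expectation rather than a measurement.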

Compound 3, half-maximal cytotoxic concentration: > 50000 nM
Compound 3: only a limit was reported; the forecaster's own chance of this, stated with the estimate: 80%; the middle value sits exactly at the limit.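

In this assay compound 3 gives > 50000 nM as a limit of the assay and not a number. Among the compounds shown here, no step among compound 1, compound 2 and compound 3 can therefore be read: the limit of > 50000 nM in this assay, at which 3 of the 3 values shown sit.

Going by these compounds, whether these three compounds differ at all in how much is tolerated, and at what concentration any of them would become cytotoxic, stays open.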